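This account rests on a few compounds, and the source may have more. Where it says the series, first, only, none or still open, it means among the compounds named here.

Three amides built on one shared core have been tested so far in a functional assay on SK-BR-3 cells (Homo sapiens) for antiproliferative activity (on this read-out higher numbers stand for weaker inhibition and lower numbers for stronger inhibition), and they give closely matching results. Compound 1 (`CC(=O)Oc1ccc(C(=O)Nc2cc3ccc(OC4CCN(C)CC4)c(C)c3oc2=O)cc1`) gives 1670 nM there, compound 2 (`CC(C)=CCc1cccc(C(=O)Nc2cc3ccc(OC4CCN(C)CC4)c(C)c3oc2=O)c1`) gives 1680 nM there, and compound 3 (`C=CCc1cc(C(=O)Nc2cc3ccc(OC4CCN(C)CC4)c(C)c3oc2=O)ccc1O`) gives 2430 nM there. Compound 1 thus stands level with both of the others. The data show a 1.0-fold higher number from compound 1 to compound 2 (0.00 log units; within the scatter) and also a 1.5-fold higher number from compound 1 to compound 3 (0.16 log units; within the scatter) and so nothing separates them.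

Compound 4 (`COc1cccc(-c2cc(C(=O)Nc3cc4ccc(OC5CCN(C)CC5)c(C)c4oc3=O)ccc2OC(C)=O)c1`) is compound 1 with one change (3-methoxyphenyl in place of hydrogen on an aromatic carbon) and its acetoxy group stays in place. Compound 2 and compound 3 bear on this change only loosely. They too differ from compound 1 in the aromatic ring on the carbonyl carbon, yet their steps stay within the scatter, and so does a 1.4-fold higher number from compound 2 to compound 3 (0.16 log units; within the scatter) between them. Neither carries a 3-methoxyphenyl group, so the data give no direct reading of what this group does. With that gap in mind, no step beyond the scatter is expected in this assay and no direction can be named, although the uncertainty is wide. The expected step is a 1.0-fold lower number from compound 1 to compound 4 (0.02 log units; within the scatter) by this estimate. Compound 4 is estimated at 1600 nM with an expected range from 550 nM to 4500 nM in this read-out.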

Compound 4, half-maximal inhibitory concentration: 920 nM
Beside the measured number, compound 4's estimate is 1.7-fold (0.24 log units) above it; measured number inside the range.
By their numbers in this assay, from the lowest: compounds 4, 1, 2 and 3 (each within the scatter of the next, the first and the last beyond it).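

In this assay, putting a 3-methoxyphenyl group on the aromatic carbon ortho to the acetoxy group gives a 1.8-fold lower number from compound 1 to compound 4 (0.26 log units; within the scatter), so the two compounds cannot be told apart on this read-out. The earlier compounds shown here carried no second aromatic ring on this part of the molecule, whereas compound 4 shows that a group of this size, a six-membered aromatic ring of carbon only with a methoxy group, can sit at this place with the acetoxy group kept and leave the number within the scatter of compound 1. No independent measurement is available that would explain this result.

From the compounds shown here alone, it remains open whether the methoxy group matters at all, or whether a plain phenyl ring, or a phenyl ring carrying an amine or a carboxylic acid instead of the methoxy group, would read the same at this place. Going by these compounds, it is also open whether the result holds when a free hydroxyl group replaces the acetoxy group while the 3-methoxyphenyl group stays.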